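Positional Swap of the Trifluoromethyl Group on the Shared Core

A few compounds are considered here, and "the series" means these few. Any claim that something is new, unique, unknown or untested is made for them only; others in the source may bear on it.

The series is built on one shared core carrying two hydroxyphenyl groups and one trifluoromethylphenyl group. Compound 1 `Oc1cccc(-c2cc(-c3cccc(C(F)(F)F)c3)cc(-c3cccc(O)c3)n2)c1` gives 12700 nM in a functional assay on HeLa cells (Homo sapiens) for inhibition; on this read-out higher numbers stand for weaker inhibition and lower numbers for stronger inhibition. Compound 2 `Oc1cccc(-c2cc(-c3ccc(C(F)(F)F)cc3)cc(-c3cccc(O)c3)n2)c1` is reported only as a limit of this assay, > 50000 nM. Compound 3 `Oc1ccc(-c2cc(-c3cccc(C(F)(F)F)c3)cc(-c3cccc(O)c3)n2)cc1` gives 16200 nM in this assay.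

The change from compound 1 to compound 2 is 4-(trifluoromethyl)phenyl in place of 3-(trifluoromethyl)phenyl on an aromatic carbon, and it produced an at least 3.9-fold higher number from compound 1 to compound 2 (0.59 log units; beyond the scatter); that the value of compound 2 sits at the limit of > 50000 nM in this assay, at which 1 of the 3 values shown sits, fixes only the lower bound of this step. The cores of compound 1 and compound 3 differ by 4-hydroxyphenyl in place of 3-hydroxyphenyl on an aromatic carbon, with a 1.3-fold higher number from compound 1 to compound 3 (0.11 log units; within the scatter).

Compound 4 `Oc1ccc(-c2cc(-c3ccc(C(F)(F)F)cc3)cc(-c3cccc(O)c3)n2)cc1` is not yet measured. It differs from compound 3 by 4-(trifluoromethyl)phenyl in place of 3-(trifluoromethyl)phenyl on an aromatic carbon. This is the same kind of change as that from compound 1 to compound 2, but not the same: there the group sits meta to two 3-hydroxyphenyl groups, here meta to a 3-hydroxyphenyl group and meta to a 4-hydroxyphenyl group.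

Compound 4 is expected to show a 3.7-fold higher number from compound 3 to compound 4 (0.57 log units; beyond the scatter) in this assay, resting on an at least 3.9-fold higher number from compound 1 to compound 2 (0.59 log units; beyond the scatter) seen for compound 2. Compound 4 is therefore estimated at 60000 nM, between 25000 nM and 150000 nM, and may itself come back only as a limit.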

Compound 4, half-maximal inhibitory concentration: 17300 nM
The estimate for compound 4 lay 3.5-fold (0.54 log units) above the measured number, and the stated range ends above it.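

With a 4-hydroxyphenyl group on the shared core, 4-(trifluoromethyl)phenyl in place of 3-(trifluoromethyl)phenyl gives a 1.1-fold higher number from compound 3 to compound 4 (0.03 log units; within the scatter) in this assay, so the step seen on the other core does not carry over: the same change on two cores in this assay, an at least 3.9-fold higher number (0.59 log units; beyond the scatter) from compound 1 to compound 2 and a 1.1-fold higher number (0.03 log units; within the scatter) from compound 3 to compound 4, at least 3.6-fold (0.56 log units) apart, beyond the scatter of two such steps. Read the other way, with 4-(trifluoromethyl)phenyl on the shared core, 4-hydroxyphenyl in place of 3-hydroxyphenyl gives an at least 2.8-fold lower number from compound 2 to compound 4 (0.46 log units; beyond the scatter), which also departs from the same change on the other core: the same change on two cores in this assay, a 1.3-fold higher number (0.11 log units; within the scatter) from compound 1 to compound 3 and an at least 2.8-fold lower number (0.46 log units; beyond the scatter) from compound 2 to compound 4, at least 3.6-fold (0.56 log units) apart, beyond the scatter of two such steps. Compound 2 is only a limit, so both gaps are lower bounds, and these four compounds show that the two changes do not act independently, but not what lies behind this: the limit of > 50000 nM in this assay, at which 1 of the 4 values shown sits.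

The compounds shown leave open whether this dependence persists when a hydroxyl group is replaced by a methoxy group or an amine, or the trifluoromethyl group by chlorine or a nitrile. Among these compounds, with only two cores compared, they also leave open how far it extends across the series.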